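Replacing propyl with 4-chlorophenyl on compound 3

This account rests on a few compounds, and the source may have more. Where it says the series, first, only, none or still open, it means among the compounds named here.

Measured compounds in a functional assay on MDA-MB-231 cells (Homo sapiens) for antiproliferative activity, read by MTT assay, with a stated time of 48 h (a higher number here means a weaker inhibitor, a lower number a stronger inhibitor), are these:
Compound 1 `C=CS(=O)(=O)N1CCN(c2ncnc3sc(-c4ccc(N5CCN(C)CC5)cc4)cc23)CC1` gives 7550 nM
Compound 2 `C=CS(=O)(=O)N1CCN(c2ncnc3sc(-c4cccc5ncccc45)cc23)CC1` gives 21000 nM
Compound 3 `CCCNC(=O)N1CCN(c2ncnc3sc(-c4ccc(N5CCN(C)CC5)cc4)cc23)CC1` gives 8330 nM

Compound 3 (8330 nM) lies within the scatter of compound 1 (7550 nM). Compound 2 (21000 nM) stands higher than compound 3, and that gap goes beyond the scatter.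

The next compound is compound 4 (`CN1CCN(c2ccc(-c3cc4c(N5CCN(C(=O)Nc6ccc(Cl)cc6)CC5)ncnc4s3)cc2)CC1`), which carries 4-chlorophenyl in place of propyl on an amide-type nitrogen. Among the compounds with values here, no measured compound shows a change of this group itself. Within the data shown here, one measured step bears on it, and only indirectly: the step (a 1.1-fold higher number from compound 1 to compound 3 (0.04 log units; within the scatter)) put propylcarbamoyl in place of vinylsulfonyl on an amine nitrogen in a ring. That exchange, at the same part of the molecule, left the number within the scatter. On that single precedent, no step beyond the scatter is expected in this assay for the new exchange, and any lean towards a lower number is only tentative. The estimate implies the expected step (a 1.4-fold lower number from compound 3 to compound 4 (0.14 log units; within the scatter)). With so little direct evidence, the range is kept wide. Compound 4 is expected at 6000 nM within an estimated range from 2000 nM to 18000 nM in this measurement.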

Compound 4, half-maximal inhibitory concentration: 5440 nM
Compound 4: the middle estimate sits 1.1-fold (0.04 log units) above what was measured; low and high end bracket the measured number.
By their numbers in this assay, from the lowest: compounds 4, 1 and 3 (each within the scatter of the next); then compound 2.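

In this assay, the first change made on the amide-type nitrogen itself replaces an open propyl chain with a chlorinated aromatic ring, and a 1.5-fold lower number from compound 3 to compound 4 (0.19 log units; within the scatter) shows that this larger group leaves the number within the scatter. Set against the vinylsulfonyl group of compound 1, a 1.4-fold lower number from compound 1 to compound 4 (0.14 log units; within the scatter) also stays within the scatter, so vinylsulfonyl, propylcarbamoyl and (4-chlorophenyl)carbamoyl on this ring nitrogen cannot be told apart in these three compounds, which share the rest of their structure. No measurement at hand accounts for this lack of separation or shows what the compounds do inside the cells.

From the compounds shown here alone, whether any group on the amide-type nitrogen can move the number beyond the scatter remains open: a plain phenyl without the chlorine would separate the contribution of the ring from that of the halogen, while a longer chain, a terminal amine or a carboxylic acid would test other kinds of substituent. Going by these compounds, it is also open whether (4-chlorophenyl)carbamoyl would behave the same way alongside the aromatic group that compound 2 carries on the shared core.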